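Chloropyridinyl amide on a flavonol core: an expected value

The source may report more compounds than this note shows. Statements on the series, on what has been measured and on what is new or still open speak of the compounds shown alone.

Compounds measured so far in a functional assay on HeLa cells (Homo sapiens) for antiproliferative activity, read by CCK-8 assay, with a stated time of 72 h; on this read-out higher numbers stand for weaker inhibition and lower numbers for stronger inhibition:
compound 1, `Cc1ccccc1C(=O)Nc1cccc(-c2oc3cc(-c4ccc(F)cc4)ccc3c(=O)c2O)c1`, 11900 nM
compound 2, `Cc1cccc(C(=O)Nc2cccc(-c3oc4cc(-c5ccc(F)cc5)ccc4c(=O)c3O)c2)c1`, 6650 nM
compound 3, `CCc1ccc(C(=O)Nc2cccc(-c3oc4cc(-c5ccc(F)cc5)ccc4c(=O)c3O)c2)cc1`, 21000 nM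

Against compound 2, compound 3 shows a 3.2-fold higher number from compound 2 to compound 3 (0.50 log units; beyond the scatter); against compound 1 the gap, a 1.8-fold higher number from compound 1 to compound 3 (0.25 log units; within the scatter), stays within the scatter, and compound 1 and compound 2 differ by a 1.8-fold lower number from compound 1 to compound 2 (0.25 log units; within the scatter). Compound 4, `O=C(Nc1cccc(-c2oc3cc(-c4ccc(F)cc4)ccc3c(=O)c2O)c1)c1ccc(Cl)nc1`, is reached from compound 3 by 6-chloropyridin-3-yl in place of 4-ethylphenyl on a carbonyl carbon. For the measured compounds named here, none of the measured steps exchanges the aromatic ring itself; all three merely move or lengthen an alkyl group on it, and those steps stayed modest. Going by the values given here, with no direct precedent, a small step is expected for compound 4 in this assay, a 1.8-fold lower number from compound 3 to compound 4 (0.24 log units; within the scatter), giving an estimate of 12000 nM with a range from 4000 nM to 40000 nM.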

Compound 4, half-maximal inhibitory concentration: 4080 nM
Beside the measured number, compound 4's estimate is 2.9-fold (0.47 log units) above it; the measured number falls inside the stated range.
By their numbers in this assay, from the lowest: compounds 4, 2, 1 and 3 (each within the scatter of the next, the first and the last beyond it).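

In this assay, 6-chloropyridin-3-yl on the carbonyl carbon is the only change shown that exchanges the aromatic ring itself, and it gives the largest step here, a 5.1-fold lower number from compound 3 to compound 4 (0.71 log units; beyond the scatter). Measured against the 2-methylphenyl amide the exchange gives a 2.9-fold lower number from compound 1 to compound 4 (0.46 log units; beyond the scatter), while against the 3-methylphenyl amide it stays within the scatter, a 1.6-fold lower number from compound 2 to compound 4 (0.21 log units; within the scatter), so this position accepts a ring with a nitrogen without a loss beyond the scatter in any comparison. Nothing available accounts for these differences.

Open, on these data alone, is whether the chlorine or the ring nitrogen carries the step, and how an amine or a carboxylic acid on this ring would read.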